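Swapping an Aromatic Ring for a Saturated One

The source may hold more compounds than are shown below. What is called first, only, known or untested is meant among the compounds shown, and "the series" means these compounds.

Compound 1 `O=C1C(Nc2ccccc2F)=CC(=O)c2c1nc1n2[C@H]2OC[C@@H](O)[C@H]2OC1` was tested in a functional assay on MCF7 cells (Homo sapiens) for inhibition, read by sulforhodamine B assay; on this read-out lower numbers stand for stronger inhibition and higher numbers for weaker inhibition. In this assay compound 1 gives only a limit, > 4000 nM, so no exact number is known for it. Compound 2 `O=C1C=C(NC2CCCCC2)C(=O)c2c1nc1n2[C@H]2OC[C@@H](O)[C@H]2OC1` also carries a cyclohexylamino group. In this assay compound 2 likewise gives only a limit, > 8000 nM. Compound 3 `O=C1C(NC2CCCCC2)=CC(=O)c2c1nc1n2[C@H]2OC[C@@H](O)[C@H]2OC1` is the partner of compound 1 with cyclohexyl in place of 2-fluorophenyl on an amine nitrogen. Among the compounds with values here, no measured pair of compounds differing in exactly this way is available, so the size of the change cannot be read from a neighbour; the two limits at the limit of > 4000 nM in this assay, at which 1 of the 2 values shown sits, and the limit of > 8000 nM in this assay, at which 1 of the 2 values shown sits, are all that can be drawn on. The step from compound 1 to compound 3 is expected to be a step that the limit leaves unreadable from compound 1 to compound 3, not beyond the scatter. Compound 3 is therefore expected to give about 8000 nM in this assay, with a likely range from 3000 nM to 30000 nM, and quite possibly only a limit once more.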

Compound 3, half-maximal inhibitory concentration: > 16000 nM
Compound 3: a limit, no number (the forecaster's own chance of this, stated with the estimate: 80%); at least 2.0-fold (0.30 log units) between middle value and limit.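

Compound 1 and compound 3 each give only a limit in this assay, so the size of the step between them, cyclohexyl in place of 2-fluorophenyl on an amine nitrogen, cannot be read. The compounds shown leave open how strongly, if at all, either compound inhibits these cells, and so whether this swap matters.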